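Vinyl in Place of Carbamoyl: Expecting a Large Drop

A few compounds are considered here, and "the series" means these few. Any claim that something is new, unique, unknown or untested is made for them only; others in the source may bear on it.

Compound 3 `CCN(C/C=C/C#CC(C)(C)C)Cc1cccc(OC[Si](C)(C)c2ccc(C(N)=O)cc2)c1` gives 5000 nM in a functional assay on liver (Sus scrofa) for inhibition of squalene monooxygenase (Homo sapiens), using microsomes (on this read-out lower numbers stand for stronger inhibition and higher numbers for weaker inhibition), and stands highest of the three numbers measured. Its nearest neighbour is compound 1 `CCN(C/C=C/C#CC(C)(C)C)Cc1cccc(OC[Si](C)(C)c2ccc(Br)cc2)c1`, which gives 210 nM; furthest from it is compound 2 `CCN(C/C=C/C#CC(C)(C)C)Cc1cccc(OC[Si](C)(C)c2ccc(C)cc2)c1`, which gives 120 nM. The two steps leading to compound 3 are both large: a 24-fold higher number from compound 1 to compound 3 (1.38 log units; beyond the scatter) and a 42-fold higher number from compound 2 to compound 3 (1.62 log units; beyond the scatter). Between the other two the step is small, a 1.8-fold lower number from compound 1 to compound 2 (0.24 log units; within the scatter).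

Compound 4 `C=Cc1ccc([Si](C)(C)COc2cccc(CN(CC)C/C=C/C#CC(C)(C)C)c2)cc1` differs from compound 3 in one place: vinyl in place of carbamoyl on an aromatic carbon, on a six-membered aromatic ring of carbon only, para to a large group. Among the measured compounds shown here, no measured step exchanges carbamoyl for vinyl directly. The measured steps that bear on it are the two that brought carbamoyl in, and both raised the number by a large margin. Compound 4 is therefore expected to show a large step in the lowering direction, a 25-fold lower number from compound 3 to compound 4 (1.40 log units; beyond the scatter), because a 42-fold higher number from compound 2 to compound 3 (1.62 log units; beyond the scatter) and a 24-fold higher number from compound 1 to compound 3 (1.38 log units; beyond the scatter) both run the opposite way when read backwards. For compound 4 the estimate in this assay is 200 nM, with a range from 60 nM to 700 nM.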

Compound 4, half-maximal inhibitory concentration: 70 nM
The estimate for compound 4 lay 2.9-fold (0.46 log units) above the measured number; low and high end bracket the measured number.
By their numbers in this assay, from the lowest: compounds 4, 2 and 1 (each within the scatter of the next, the first and the last beyond it); then compound 3.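

Among the compounds shown here, with vinyl on this aromatic carbon, the loss seen with carbamoyl in this assay is removed in full: a 71-fold lower number from compound 3 to compound 4 (1.85 log units; beyond the scatter), and carbamoyl is now the one group of the four whose number stands far from all the others. The vinyl result also separates the groups that keep a low number, since a 1.7-fold lower number from compound 2 to compound 4 (0.23 log units; within the scatter) stays within the scatter, while a 3.0-fold lower number from compound 1 to compound 4 (0.48 log units; beyond the scatter) is a modest step beyond it, so vinyl cannot be ordered against methyl but does give a lower number than bromo. Carbamoyl carries a hydrogen-bond donor and acceptor where vinyl has none, but this count alone does not explain the difference, and nothing at hand gives a measured reason for it.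

The compounds shown leave open whether the large rise belongs to carbamoyl alone or would also come with a carboxylic acid, a methyl ester, a nitrile or an aminomethyl group at this place. They also leave open how an ethyl group or a longer chain such as propyl would compare with vinyl and methyl, and whether the same steps would hold on any other core.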